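Hydroxy for fluoro on a ninhydrin-type core

The compounds below may be only part of what the source reports. "The series", "measured", "known", "first", "only" and "open" are said of these compounds alone.

Measured so far:
compound 1 `O=C1c2cccc(F)c2C(=O)C1(O)O` — > 100000 nM
compound 2 `O=C1c2ccc(F)cc2C(=O)C1(O)O` — > 100000 nM

Both compounds carry the same hydrated triketone core with a single fluoro substituent on the carbon ring. In an assay on isolated protein for inhibition of carbonic anhydrase 4 (Homo sapiens), read by stopped-flow, with a stated time of 15 min (on this read-out higher numbers stand for weaker inhibition and lower numbers for stronger inhibition), compound 1 gives > 100000 nM, which is a limit of the assay and not a number. Compound 2 likewise gives only a limit in this assay, > 100000 nM. Compound 2 therefore stands at the weak end of what has been seen: the limit of > 100000 nM in this assay, at which 2 of the 2 values shown sit, so no measured step between compounds is available and nothing in the shown numbers orders compound 1 and compound 2 against each other.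

The next compound, compound 3 `O=C1c2ccc(O)cc2C(=O)C1(O)O`, keeps the core of compound 2 and carries the change (hydroxy in place of fluoro on an aromatic carbon), that is, hydroxy in place of fluoro on an aromatic carbon.

Among the compounds with values here, with no measured step to lean on, the expectation is a move toward stronger inhibition in this assay, of moderate size and with wide uncertainty, because compound 2 sits only at a limit > 100000 nM. For compound 3 the estimate in this assay is 30000 nM, within 3000 nM to 300000 nM. The step this estimate means is an at least 3.3-fold lower number from compound 2 to compound 3 (0.52 log units; beyond the scatter), with a real chance that compound 3 again returns only a limit.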

Compound 3, inhibition constant: > 100000 nM
Compound 3: a limit, no number; the forecaster's own chance of this, stated with the estimate: 45%; at least 3.3-fold (0.52 log units) between middle value and limit.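

In this assay compound 3 gives > 100000 nM, a limit of the assay and not a number. Compound 2 also stands at a limit, so no step can be read between compound 2 and compound 3. The compounds shown leave open whether any substituent on the shared core gives a readable number in this assay, as all stand together: the limit of > 100000 nM in this assay, at which 3 of the 3 values shown sit.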